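Swapping benzylsulfanyl for aminoamino in compound 2

A few compounds are considered here, and "the series" means these few. Any claim that something is new, unique, unknown or untested is made for them only; others in the source may bear on it.

Compound 1 `CC1=C(C(=O)Nc2ccc(C)cc2)C(c2ccc(O)cc2O)NC(SCc2ccccc2)=N1`: 20800 nM
Compound 2 `CC1=C(C(=O)Nc2cccc([N+](=O)[O-])c2)C(c2ccc(O)cc2O)NC(SCc2ccccc2)=N1`: > 100000 nM (a limit)
Compound 3 `CC1=C(C(=O)Nc2cccc([N+](=O)[O-])c2)C(c2ccc(O)cc2O)NC(Nc2ccc(S(=O)(=O)Nc3nc(C)cc(C)n3)cc2)=N1`: 3940 nM

In a functional assay on A-431 cells (Homo sapiens) for inhibition, read by sulforhodamine B assay, with a stated time of 2 days (on this read-out higher numbers stand for weaker inhibition of growth and lower numbers for stronger inhibition of growth), compound 2 gives > 100000 nM, which is a limit and not a number. Compound 4 `CC1=C(C(=O)Nc2cccc([N+](=O)[O-])c2)C(c2ccc(O)cc2O)NC(NN)=N1` carries aminoamino in place of benzylsulfanyl on a carbon with a double bond to nitrogen. For the measured compounds named here, the only measured step, an at least 4.8-fold higher number from compound 1 to compound 2 (0.68 log units; beyond the scatter), concerns an amide-type nitrogen, not this carbon, so it gives no direct size. With the same 3-nitrophenyl but another group on that carbon, compound 3 gives 3940 nM, so a moderate move toward stronger inhibition is expected in this assay. The estimated step is an at least 2.8-fold lower number from compound 2 to compound 4 (0.45 log units; beyond the scatter). For compound 4 the expected value is 35000 nM, with an estimated range from 9000 nM to 100000 nM.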

Compound 4, concentration for 50% growth inhibition: 24300 nM
Compound 4: middle estimate off by 1.4-fold (0.16 log units), on the high side; measured number inside the range.
By their numbers in this assay, from the lowest: compound 3; then compounds 1 and 4 (each within the scatter of the next). At a limit, above all of these: compound 2.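

In this assay the change gives an at least 4.1-fold lower number from compound 2 to compound 4 (0.61 log units; beyond the scatter). So at this carbon, between two ring nitrogen atoms, benzylsulfanyl and its aromatic ring are not needed for a measurable value, and the much smaller aminoamino is enough. This step has only a lower bound, because compound 2 stands at a limit, not at a number: the limit of > 100000 nM in this assay, at which 1 of the 4 values shown sits.

From the compounds shown here alone, what remains open is whether the shift comes from losing benzylsulfanyl or from adding aminoamino. A plain amine or a methyl group on this carbon would help separate the two.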